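This account rests on a few compounds, and the source may have more. Where it says the series, first, only, none or still open, it means among the compounds named here.

In a physicochemical assay for solubility, read by HPLC, in phosphate buffer, measured as thermodynamic solubility, with a stated time of 24 h, at pH 7.4 (on this read-out lower numbers stand for lower solubility and higher numbers for higher solubility), compound 2 `C[C@@H]1CN([C@@H](C)CO)C(=O)c2cccc(NC(=O)Nc3cncc4ccccc34)c2O[C@H]1CN(C)S(=O)(=O)c1ccc2c(c1)OCCO2` gives 84900 nM and compound 3 `C[C@@H]1CN([C@@H](C)CO)C(=O)c2cccc(NC(=O)Nc3cccc4cnccc34)c2O[C@H]1CN(C)S(=O)(=O)c1ccc2c(c1)OCCO2` gives 60500 nM, so the pair shares the top of the measured range. Far under them stands compound 1 `C[C@@H]1CN([C@@H](C)CO)C(=O)c2cccc(NC(=O)NCc3cccc4ccccc34)c2O[C@H]1CN(C)S(=O)(=O)c1ccc2c(c1)OCCO2` with 100 nM, and the steps out of it are an 850-fold higher number from compound 1 to compound 2 (2.93 log units; beyond the scatter) and a 610-fold higher number from compound 1 to compound 3 (2.78 log units; beyond the scatter). Compound 4 `C[C@@H]1CN([C@@H](C)CO)C(=O)c2cccc(NC(=O)Nc3cccc4ccncc34)c2O[C@H]1CN(C)S(=O)(=O)c1ccc2c(c1)OCCO2` departs from compound 2 by isoquinolin-8-yl in place of isoquinolin-4-yl on an amide-type nitrogen. The two large steps from compound 1 replace (naphthalen-1-yl)methyl, which is not the change at issue here. Going by the values given here, the closest precedent is the exchange of isoquinolin-4-yl for isoquinolin-5-yl, which gave a 1.4-fold lower number from compound 2 to compound 3 (0.15 log units; within the scatter). On that single comparison, no step beyond the scatter is expected in this assay, and no direction can be called. The step expected here is a 1.3-fold lower number from compound 2 to compound 4 (0.12 log units; within the scatter). The value expected for compound 4 is an estimated 65000 nM, with a range of 20000 nM to 150000 nM.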

Compound 4, solubility: 101000 nM
Compound 4: the middle estimate sits 1.6-fold (0.19 log units) below what was measured, and the stated range covers the measured number.
By their numbers in this assay, from the lowest: compound 1; then compounds 3, 2 and 4 (each within the scatter of the next).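

In this assay, isoquinolin-8-yl on the amide-type nitrogen gives a 1.2-fold higher number from compound 2 to compound 4 (0.08 log units; within the scatter) and a 1.7-fold higher number from compound 3 to compound 4 (0.22 log units; within the scatter), so a third isoquinolinyl group joins isoquinolin-4-yl and isoquinolin-5-yl with no step beyond the scatter among the three. The exchange from (naphthalen-1-yl)methyl also stays large with this group, at a 1000-fold higher number from compound 1 to compound 4 (3.00 log units; beyond the scatter), and that large step now holds for all three isoquinolinyl groups shown. Nothing available explains these numbers. From the compounds shown here alone, in each large step, the ring system and the methyl link change together, so it remains open whether naphthalen-1-yl or (isoquinolin-4-yl)methyl on the same nitrogen would read with compound 1 or with compounds 2, 3 and 4. Also open, going by these compounds, is how a pyridinyl group, or an isoquinolinyl group carrying an amine, would read in this assay.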